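The source may report more compounds than this note shows. Statements on the series, on what has been measured and on what is new or still open speak of the compounds shown alone.

Measured in an ADME assay on TZM-b1 cells (Homo sapiens) for cytotoxicity, read by XTT assay, with a stated time of 3 days; on this read-out lower numbers stand for higher toxicity in this test and higher numbers for lower toxicity in this test:
- compound 1 `Cc1nc(C(NC(=O)C(=O)Nc2ccc(F)c(Cl)c2)C2CCCCN2)sc1CO`: > 77800 nM (a limit of the assay, not a number)
- compound 2 `Cc1nc(C(NC(=O)C(=O)Nc2ccc(Cl)c(F)c2)C2CCCCN2)sc1CO`: 58400 nM

Within the data shown here, compound 2, at 58400 nM, holds the only actual number so far. For compound 1 the reading is a limit: the limit of > 77800 nM in this assay, at which 1 of the 2 values shown sits.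

The next compound is compound 3 `Cc1nc(C(NC(=O)C(=O)Nc2ccc(F)cc2)C2CCCCN2)sc1CO`, where 4-fluorophenyl stands in place of 4-chloro-3-fluorophenyl on an amide-type nitrogen: 4-fluorophenyl in place of 4-chloro-3-fluorophenyl on an amide-type nitrogen.

Among the measured compounds shown here, only one measured step bears on this change, and only loosely: an at least 1.3-fold lower number from compound 1 to compound 2 (0.12 log units; that floor lies within the scatter). That step exchanges 3-chloro-4-fluorophenyl for 4-chloro-3-fluorophenyl on the same nitrogen and stays within the scatter. For the measured compounds named here, no measured step goes to 4-fluorophenyl, so the size of this change in this assay is not directly known. With so little evidence, no step beyond the scatter is expected in either direction, and the reading may again be only a limit. The expected change is a 1.2-fold higher number from compound 2 to compound 3 (0.08 log units; within the scatter). Compound 3 is estimated at 70000 nM, with an expected range of 35000 nM to 140000 nM.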

Compound 3, half-maximal cytotoxic concentration: > 90000 nM
Compound 3 ended at the assay's limit; the forecaster's own chance of this, stated with the estimate: 50%; at least 1.2-fold (0.10 log units) between middle value and limit.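

Going to 4-fluorophenyl on the amide-type nitrogen gives an at least 1.5-fold higher number from compound 2 to compound 3 (0.18 log units; that floor lies within the scatter) in this assay, so the loss of the chloro from 4-chloro-3-fluorophenyl produces no printed step beyond the scatter at this position. Compound 3 reads as a limit of the assay, > 90000 nM. The step from compound 1 to compound 3, hydrogen in place of chloro on an aromatic carbon, cannot be read, since both of its ends are limits: the limit of > 90000 nM in this assay, at which 1 of the 3 values shown sits.

Among these compounds, all three compounds carry a fluorinated phenyl on this nitrogen and only compound 2 gives an actual number, so the series so far shows no step at this position that is known to exceed the scatter. From the compounds shown here alone, whether a plain phenyl, or a phenyl bearing an amine or a carboxylic acid, would bring the reading in this assay to a clear number and a readable step remains open.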